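Fluoro at the para position on two related oxime-ether cores

The source may hold more compounds than are shown below. What is called first, only, known or untested is meant among the compounds shown, and "the series" means these compounds.

Working notes on a small series measured in a functional assay on SK-HEP1 cells (Homo sapiens) for antiproliferative activity; on this read-out higher numbers stand for weaker inhibition of growth and lower numbers for stronger inhibition of growth. Compound 1 `O=c1c(-c2ccccc2)coc2cc(OC/C(=N/O)c3ccccc3)ccc12` gives 6400000 nM in this assay. Compound 2 `O=c1c(-c2ccccc2)coc2cc(OC/C(=N/O)c3ccc(F)cc3)ccc12` carries the change fluoro in place of hydrogen on an aromatic carbon and gives 6610000 nM; the step of a 1.0-fold higher number from compound 1 to compound 2 (0.01 log units; within the scatter) is flat. Compound 3 `CO/N=C(/COc1ccc2oc(-c3ccccc3)cc(=O)c2c1)c1ccccc1` belongs to a second core; the difference between the two cores is not broken down here. In this assay compound 3 gives 8200000 nM, and its gaps to compound 1 and compound 2 both sit within the scatter, so no order among the three is claimed.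

Compound 4 `CO/N=C(/COc1ccc2oc(-c3ccccc3)cc(=O)c2c1)c1ccc(F)cc1` is not yet measured. Relative to compound 3 it carries fluoro in place of hydrogen on an aromatic carbon, the same kind of change already seen between compound 1 and compound 2, on the same kind of place. The expectation for compound 4 rests on that single earlier step, a 1.0-fold higher number from compound 1 to compound 2 (0.01 log units; within the scatter), which was flat; the expected step is a 1.0-fold higher number from compound 3 to compound 4 (0.01 log units; within the scatter). Compound 4 is therefore estimated at 8300000 nM, with a range of 4000000 nM to 17000000 nM.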

Compound 4, concentration for 50% growth inhibition: 7910000 nM
The estimate for compound 4 lay 1.0-fold (0.02 log units) above the measured number, within the range that was stated.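

In this assay, the change from phenyl to 4-fluorophenyl on the second core gives a 1.0-fold lower number from compound 3 to compound 4 (0.02 log units; within the scatter), so this step is flat as well. Set beside the earlier step, the change reads the same on both cores, with no gap beyond the scatter: the same change on two cores in this assay, a 1.0-fold higher number (0.01 log units; within the scatter) from compound 1 to compound 2 and a 1.0-fold lower number (0.02 log units; within the scatter) from compound 3 to compound 4, 1.1-fold (0.03 log units) apart, within the scatter of two such steps. This shows that a flat fluoro step carried across these two pairs, but it rests on one change in a single assay, and two flat steps do not show that a step of real size would carry from one core to the other.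

Still open, going by these compounds, is how other groups at the same place would behave, such as an amine, a carboxylic acid or a longer chain in place of the fluoro, and whether any of them would give a step beyond the scatter on either core. Also open is which part of the difference between the two cores, if any, bears on this read-out, as no pair shown isolates a single change between them.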